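The compounds below may be only part of what the source reports. "The series", "measured", "known", "first", "only" and "open" are said of these compounds alone.

Measured in an ADME assay on microsomes from liver (Homo sapiens) for metabolic stability, with a stated time of 10 min; on this read-out higher numbers stand for a more stable compound and lower numbers for a less stable compound:
compound 1 `Fc1ccccc1-c1ccc2[nH]c(C3=NOC4(CCCCC4)C3)nc2c1`: 79%
compound 2 `FC(F)(F)Oc1ccccc1-c1ccc2[nH]c(C3=NOC4(CCCCC4)C3)nc2c1`: 100%
compound 3 `Fc1cccc(OC(F)(F)F)c1-c1ccc2[nH]c(C3=NOC4(CCCCC4)C3)nc2c1`: 100%

Compound 2 is level with compound 3, and together they hold the highest number of the three. Compound 4 `CC(C)(O)c1ccccc1-c1ccc2[nH]c(C3=NOC4(CCCCC4)C3)nc2c1` has 1-hydroxy-1-methylethyl in place of trifluoromethoxy on an aromatic carbon. Going by the values given here, no measured compound carries this new group, so the evidence is indirect. Trifluoromethoxy in place of fluoro gave a number 21 percentage points higher from compound 1 to compound 2 (beyond the scatter), a modest step beyond the scatter. Trifluoromethoxy in place of hydrogen gave a number 21 percentage points higher from compound 1 to compound 3 (beyond the scatter), also modest, while the added fluoro gave no change at the digits printed from compound 2 to compound 3 (within the scatter). Losing trifluoromethoxy may therefore cost a similar amount, so a modest fall is expected, an estimated a number 17 percentage points lower from compound 2 to compound 4 (beyond the scatter). Compound 4 is expected at 83%, within an estimated range of 62% to 100%.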

Compound 4, percent of the compound remaining: 44%
Estimate against measurement, compound 4: 39 percentage points above, outside the stated range (below it).
By their numbers in this assay, from the lowest: compound 4; then compound 1; then compounds 2 and 3 (each within the scatter of the next).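

At this position, ortho to a large group, the choice of group can also push the number down: in this assay, 1-hydroxy-1-methylethyl in place of trifluoromethoxy gives a number 56 percentage points lower from compound 2 to compound 4 (beyond the scatter), and in place of fluoro it gives a number 35 percentage points lower from compound 1 to compound 4 (beyond the scatter). The earlier compounds shown here showed only a rise, so this change reveals a wider spread at this position than they suggested. Nothing available gives a reason for the fall.

Still open, as far as these compounds go, is whether the fall follows the hydroxyl or the branched carbons. A tert-butyl group at this position would tell these apart.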